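This account rests on a few compounds, and the source may have more. Where it says the series, first, only, none or still open, it means among the compounds named here.

Measured compounds:
Compound 1 `O=C(N/N=C\c1ccccn1)c1ccc(-c2nc3ccccc3s2)cc1` gives 10200 nM.
Compound 2 `O=C(N/N=C/c1ccc(O)cc1O)c1ccc(-c2nc3ccccc3s2)cc1` gives 5580 nM.

In an assay on isolated protein for inhibition of Maltase-glucoamylase (Homo sapiens), with a stated time of 15 min (a lower number here means a stronger inhibitor, a higher number a weaker inhibitor), compound 2 holds the lowest of the two numbers recorded so far, and its nearest neighbour is compound 1, whose number is higher by an amount that stays within the scatter of repeated measurements. The two measured values therefore cannot be ordered against one another.

Compound 3 `COc1ccc(/C=N/NC(=O)c2ccc(-c3nc4ccccc4s3)cc2)cc1` is not yet measured. It differs from compound 2 in one place: 4-methoxyphenyl in place of 2,4-dihydroxyphenyl on a carbon with a double bond to nitrogen. Among the compounds with values here, no step between measured compounds is available for this change, so the expectation rests on the two values at hand. Since compound 1, which carries no hydroxyl groups at all, gives 10200 nM, a number close to that of compound 2, the step is expected to be small. Compound 3 is estimated at 8000 nM, with a range from 3000 nM to 25000 nM, and the expected step is a 1.4-fold higher number from compound 2 to compound 3 (0.16 log units; within the scatter), which is not expected to exceed the scatter.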

Compound 3, half-maximal inhibitory concentration: 18300 nM
Estimate against measurement, compound 3: 2.3-fold (0.36 log units) below; low and high end bracket the measured number.
By their numbers in this assay, from the lowest: compounds 2, 1 and 3 (each within the scatter of the next, the first and the last beyond it).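

In this assay, within the data shown here, 4-methoxyphenyl in place of 2,4-dihydroxyphenyl on a carbon with a double bond to nitrogen gives a 3.3-fold higher number from compound 2 to compound 3 (0.52 log units; beyond the scatter) and thus the only step here that lies beyond the scatter, which shows that the number responds to a change at this position. The two groups differ in their oxygen atoms, hydrogen-bond donors and hydrogen-bond acceptors, so this single step cannot separate the contribution of any one of these differences. Nothing measured here accounts for the step.

The compounds shown leave open whether 4-hydroxyphenyl or 2-hydroxyphenyl alone would match compound 2 or compound 3. They also leave open how an amine or a carboxylic acid on the same ring would read.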